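A few compounds are considered here, and "the series" means these few. Any claim that something is new, unique, unknown or untested is made for them only; others in the source may bear on it.

Compound 2 `O=S(=O)(NCCCNCc1ccc(Br)cc1)c1cc(C(F)(F)F)cc(C(F)(F)F)c1` belongs to a small set built on one shared core, in which a bis(trifluoromethyl)phenylsulfonamide is joined through a three-carbon chain to a benzylamine. In a functional assay on HT-29 cells (Homo sapiens) for inhibition, read by MTT assay, with a stated time of 72 h (on this read-out higher numbers stand for weaker inhibition of growth and lower numbers for stronger inhibition of growth), compound 2 gives 2200 nM. For the measured compounds named here, its only companion with a number is compound 1 `CC(C)(C)c1ccc(CNCCCNS(=O)(=O)c2cc(C(F)(F)F)cc(C(F)(F)F)c2)cc1`, which in this assay gives 2000 nM; the two values lie within the scatter of each other, as the step of a 1.1-fold higher number from compound 1 to compound 2 (0.04 log units; within the scatter) shows, so neither can be set above the other on this read-out.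

Compound 3 `O=S(=O)(NCCCNCc1ccc(-c2ccccc2)cc1)c1cc(C(F)(F)F)cc(C(F)(F)F)c1` is the next member, not yet measured. It differs from compound 2 by phenyl in place of bromo on an aromatic carbon. Going by the values given here, the only measured step that bears on this position is a 1.1-fold higher number from compound 1 to compound 2 (0.04 log units; within the scatter), where a bulky tert-butyl and a bromo gave numbers within the scatter; nothing measured tells how a phenyl at this place behaves. On that slender basis, compound 3 is expected to stay close to compound 2, with a step of a 1.1-fold lower number from compound 2 to compound 3 (0.04 log units; within the scatter) that need not exceed the scatter. The estimate for compound 3 in this assay is 2000 nM, within a range from 800 nM to 6000 nM.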

Compound 3, concentration for 50% growth inhibition: 2300 nM
Beside the measured number, compound 3's estimate is 1.2-fold (0.06 log units) below it, and the stated range covers the measured number.
By their numbers in this assay, from the lowest: compounds 1, 2 and 3 (each within the scatter of the next).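

In this assay the change from bromo to phenyl, which puts a six-membered aromatic ring of carbon only on the aromatic carbon para to a large group, gives a 1.0-fold higher number from compound 2 to compound 3 (0.02 log units; within the scatter) and so does not move the number beyond the scatter, and the comparison with the tert-butyl compound gives a 1.2-fold higher number from compound 1 to compound 3 (0.06 log units; within the scatter) with the same outcome. The earlier pair showed only that tert-butyl and bromo could not be told apart at this place; the three groups now cannot be told apart from one another, and this holds even for a group that brings a whole aromatic ring. Nothing given here offers a reason why the numbers stay so close together.

From the compounds shown here alone, all three groups at this place carry no hydrogen-bond donors or acceptors and no net charge, so it remains open whether the numbers would stay within the scatter with an amine, a carboxylic acid or a hydroxyl group there. The compounds shown also leave open what a longer chain between the sulfonamide and the benzylamine, or a group other than the two trifluoromethyl groups on the sulfonyl-bearing ring, would do in this assay on this read-out.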